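The source may report more compounds than this note shows. Statements on the series, on what has been measured and on what is new or still open speak of the compounds shown alone.

Compound 1, `CCc1ccc(-c2nc3c(=O)n(C)c(=O)n(C)c3[nH]2)cc1`: 0.8 nM
Compound 2, `Cn1c(=O)c2nc(-c3ccc4ccccc4c3)[nH]c2n(C)c1=O`: 5.5 nM

In an assay for binding affinity to adenosine receptor A1 (Bos taurus) (a lower number here means a stronger inhibitor, a higher number a weaker inhibitor), compound 1 gives the lowest number of the two; compound 2 gives a higher number, and that gap lies beyond the scatter. Compound 3, `Cn1c(=O)c2nc(-c3ccc([N+](=O)[O-])cc3)[nH]c2n(C)c1=O`, has not been measured yet. It differs from compound 1 in one place: nitro in place of ethyl on an aromatic carbon. Within the data shown here, no pair of measured compounds shows what this change does on its own, so the expectation rests on compound 1 alone. Because compound 1 gives 0.8 nM, compound 3 is expected to land somewhat higher, a moderate step upward in this assay. The expected step of a 10-fold higher number from compound 1 to compound 3 (1.00 log units; beyond the scatter) reflects this. Compound 3 is estimated at 8 nM, with a range from 2 nM to 40 nM.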

Compound 3, half-maximal inhibitory concentration: 8 nM
For compound 3 middle estimate and measured number coincide at the digits printed; measured number inside the range.
By their numbers in this assay, from the lowest: compound 1; then compounds 2 and 3 (each within the scatter of the next).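

In this assay, the position para to a large group on the six-membered aromatic ring turns out to be sensitive to the group it carries: nitro in place of ethyl gives a 10-fold higher number from compound 1 to compound 3 (1.00 log units; beyond the scatter). Even so, compound 3 still gives a low number, 8 nM, so the ethyl is not essential for binding in this series. Nothing measured here gives a reason for the step.

Two groups at one position cannot show a trend. An amine, a methoxy or a longer chain such as propyl in this place would show whether the step follows from the arrival of nitro or from the departure of ethyl.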